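A few compounds are considered here, and "the series" means these few. Any claim that something is new, unique, unknown or untested is made for them only; others in the source may bear on it.

Among the three compounds measured in an assay for inhibition of kynurenine 3-monooxygenase (Homo sapiens), read by mass spectrometry, with a stated time of 1 h (on this read-out lower numbers stand for stronger inhibition and higher numbers for weaker inhibition), compound 3 `C[C@@H](Oc1cc2oc(=O)n(CCC(=O)O)c2cc1Cl)c1cccnn1` stands lowest, giving 1.26 nM. Compound 1 `CCc1cc2oc(=O)n(CCC(=O)O)c2cc1Cl` gives 10 nM, and compound 2 `CC(C)Cc1cc2oc(=O)n(CCC(=O)O)c2cc1Cl` gives 12.6 nM; the step from compound 1 to compound 2 was a 1.3-fold higher number from compound 1 to compound 2 (0.10 log units; within the scatter), so enlarging the saturated chain there changed little. Compound 4 `O=C(O)CCn1c(=O)oc2cc(OCC3CC3)c(Cl)cc21` differs from compound 3 by a group of 4 heavy atoms (4 carbon; one three-membered non-aromatic ring of carbon only) in place of a group of 8 heavy atoms (6 carbon, 2 nitrogen; one six-membered aromatic ring with 2 hetero atoms), on an oxygen on an aromatic ring. Going by the values given here, no measured step covers this exchange directly; what the values of compound 1 and compound 3 show is that the shared core without the aromatic ring on that oxygen sits higher. The step in this assay from compound 3 to compound 4 is therefore expected to be a 6.3-fold higher number from compound 3 to compound 4 (0.80 log units; beyond the scatter), towards a higher number. Compound 4 is estimated at 8 nM, with a range from 2.5 nM to 25 nM.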

Compound 4, half-maximal inhibitory concentration: 10 nM
Estimate against measurement, compound 4: 1.3-fold (0.10 log units) below, within the range that was stated.
By their numbers in this assay, from the lowest: compound 3; then compounds 1, 4 and 2 (each within the scatter of the next).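

With cyclopropylmethyl on an oxygen on an aromatic ring, the step is a 7.9-fold higher number from compound 3 to compound 4 (0.90 log units; beyond the scatter), which shows that the oxygen alone does not bring the low number of compound 3; the group that leaves, with its six-membered aromatic ring with 2 hetero atoms, is tied to that number. Cyclopropylmethoxy in place of ethyl gives no change at the digits printed from compound 1 to compound 4 (within the scatter), and in place of isobutyl gives a 1.3-fold lower number from compound 2 to compound 4 (0.10 log units; within the scatter), so here the oxygen-linked group matches the two carbon-linked ones. No measurement at hand accounts for these steps. The compounds shown leave open whether a benzyl group on that oxygen would hold the low number without the ring nitrogens, and whether the opposite configuration at the stereocentre would do so.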